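Adding a Methyl to the Fluorophenyl Agonist

A few compounds are considered here, and "the series" means these few. Any claim that something is new, unique, unknown or untested is made for them only; others in the source may bear on it.

Three measured compounds share the same acid end and differ further out. Compound 1 `Cc1cccc(-c2noc(COc3ccc(CCC(=O)O)cc3Cl)n2)c1` gives 4580 nM in a functional assay on CHO cells for agonist activity at Free fatty acid receptor 1 (Homo sapiens), read by FLIPR and calcium flux, in the presence of a further agent that is not named here; a higher number here means that more compound is needed for the effect, a lower number that less compound is needed. Compound 2 `O=C(O)CCc1ccc(OCc2ncc(-c3ccccc3)o2)cc1` gives 1600 nM in this assay. Compound 3 `O=C(O)CCc1ccc(OCc2nc(-c3ccc(F)cc3)no2)cc1` gives 680 nM in this assay, the lowest of the three numbers; its gaps to compound 2 and to compound 1 both lie beyond the scatter, so compound 3 is the most potent of the three.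

Compound 4 `Cc1cc(-c2noc(COc3ccc(CCC(=O)O)cc3)n2)ccc1F` has not yet been measured. It differs from compound 3 by methyl in place of hydrogen on an aromatic carbon. Among the measured compounds shown here, no measured pair in this set shows what such an addition does, so the size of the step cannot be read from the data. Because compound 3 already gives 680 nM, one expects the small change to move the number only modestly in this assay, within the scatter or a little lower. The step of a 1.2-fold lower number from compound 3 to compound 4 (0.09 log units; within the scatter) is expected to be small. Compound 4 is therefore estimated at 550 nM, with a range from 220 nM to 1400 nM.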

Compound 4, half-maximal effective concentration: 2120 nM
Beside the measured number, compound 4's estimate is 3.9-fold (0.59 log units) below it, and the stated range ends below it.
By their numbers in this assay, from the lowest: compound 3; then compounds 2 and 4 (each within the scatter of the next); then compound 1.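

Among the compounds shown here, the change from 4-fluorophenyl to 4-fluoro-3-methylphenyl is the only single-place step in this set. In this assay, a methyl on the aromatic carbon ortho to a fluoro group and meta to a large group gives a 3.1-fold higher number from compound 3 to compound 4 (0.49 log units; beyond the scatter), so this position does not tolerate even this one added carbon without a loss of potency beyond the scatter. Nothing available explains that loss.

The compounds shown leave open whether a chloro, methoxy or ethyl group on this same carbon would give a step of similar size. They also leave open whether the methyl would cost as much without the fluoro group, or on the unsubstituted phenyl ring of compound 2.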